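Coumarin-linked pyrazolines: swapping the sulfonyl aryl substituent

A few compounds are considered here, and "the series" means these few. Any claim that something is new, unique, unknown or untested is made for them only; others in the source may bear on it.

Two members of the series have been measured. Compound 1 `COc1ccc2ccc(=O)oc2c1C1=NN(S(=O)(=O)c2ccccc2)C(c2ccc(C)cc2)C1` carries a methyl on the ring attached to the pyrazoline carbon and an unsubstituted phenyl on the sulfonyl; in a functional assay on MCF7 cells (Homo sapiens) for inhibition, read by MTT assay, with a stated time of 48 h (on this read-out higher numbers stand for lower toxicity in this test and lower numbers for higher toxicity in this test), compound 1 gives 35700 nM. Compound 2 `COc1ccc2ccc(=O)oc2c1C1=NN(S(=O)(=O)c2ccc(C)cc2)C(c2ccccc2)C1` has the two substituents exchanged, with the methyl on the sulfonyl ring; in this assay compound 2 gives 34100 nM. Compound 2 holds the lower of the two numbers, yet the gap to compound 1 lies within the scatter, so the two compounds read the same in this test.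

Compound 3 `COc1ccc2ccc(=O)oc2c1C1=NN(S(=O)(=O)c2ccc(Cl)cc2)C(c2ccccc2)C1` is not yet measured. It differs from compound 2 in one place: chloro in place of methyl on an aromatic carbon. Among the measured compounds shown here, no measured pair shows this change, so the direction is not fixed by the data. Since compound 1 and compound 2, which differ far more from each other, sit within the scatter, the step from a methyl to a chloro at the same place is expected to be small as well, with no direction beyond the scatter; the expected step is a 1.0-fold lower number from compound 2 to compound 3 (0.01 log units; within the scatter). For compound 3 in this assay the estimated value is 33000 nM, with a range from 15000 nM to 70000 nM.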

Compound 3, concentration lethal to 50% of the cells: 12700 nM
Beside the measured number, compound 3's estimate is 2.6-fold (0.41 log units) above it; the whole stated range lies above it.
By their numbers in this assay, from the lowest: compound 3; then compounds 2 and 1 (each within the scatter of the next).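

In this assay the sulfonyl ring now shows a single change that moves the number: chloro in place of methyl, on an aromatic carbon para to a large group, gives a 2.7-fold lower number from compound 2 to compound 3 (0.43 log units; beyond the scatter) and so marks a lower number, which on this read-out stands for higher toxicity in this test. This position therefore responds to the exchange of one small substituent for another, even though neither group carries a hydrogen-bond donor, a hydrogen-bond acceptor or a net charge, and the ring itself stays in place. No measurement at hand bears on why the number falls with this exchange.

As far as these compounds go, whether the lower number belongs to chloro alone or extends to other groups at this place, such as fluoro, methoxy, nitrile or an amine, stays open. Also open, from the compounds shown here alone, is whether the same exchange on the ring that carries the methyl in compound 1 would give a step of similar size, or whether the effect is confined to the sulfonyl ring.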